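A few compounds are considered here, and "the series" means these few. Any claim that something is new, unique, unknown or untested is made for them only; others in the source may bear on it.

So far, two compounds with the same core have been tested in a functional assay on MCF7 cells (Homo sapiens) for antiproliferative activity, read by MTT assay, with a stated time of 24 h; a lower number here means a stronger inhibitor, a higher number a weaker inhibitor. Compound 1 `CCn1c(C(=O)NCC(=O)OC)ccc1C(CC)(CC)c1ccc(OCS(=O)(=O)c2ccccc2)c(C)c1` reads > 50000 nM, which is a limit of the assay and not a number. Within the data shown here, compound 2 `CCn1c(C(=O)NCCN)ccc1C(CC)(CC)c1ccc(OCS(=O)(=O)c2ccccc2)c(C)c1` gives 6470 nM, the only true number available.

Compound 3 `CCn1c(C(=O)N[C@H](C)CO)ccc1C(CC)(CC)c1ccc(OCS(=O)(=O)c2ccccc2)c(C)c1` has not yet been measured. It differs from compound 2 on the amide-type nitrogen: 1-(hydroxymethyl)ethyl in place of 2-aminoethyl on an amide-type nitrogen. In short, 1-(hydroxymethyl)ethyl takes the place of 2-aminoethyl, and a defined stereocentre enters.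

Among the measured compounds shown here, the one measured step that bears on this is an at least 7.7-fold lower number from compound 1 to compound 2 (0.88 log units; beyond the scatter), with aminomethyl in place of methoxycarbonyl on a saturated chain carbon bound to an amide-type nitrogen, and since compound 3 has no such amino group, part of that step is expected to be undone. Going by these compounds, the full size of the step from compound 1 stays unknown because of the limit of > 50000 nM in this assay, at which 1 of the 2 values shown sits. A single step is thin support, so the expectation is loose. The expected change is a 3.4-fold higher number from compound 2 to compound 3 (0.53 log units; beyond the scatter), towards a weaker inhibitor. For compound 3 the estimated value is 22000 nM, with an expected range of 8000 nM to 50000 nM.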

Compound 3, half-maximal inhibitory concentration: 10600 nM
Compound 3: the middle estimate sits 2.1-fold (0.32 log units) above what was measured, within the range that was stated.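

In this assay, 1-(hydroxymethyl)ethyl can stand on the amide-type nitrogen in place of 2-aminoethyl without a difference that can be told from the usual scatter: a 1.6-fold higher number from compound 2 to compound 3 (0.21 log units; within the scatter). The amine of compound 2 is therefore not required for a value in this range, and the step away from the (methoxycarbonyl)methyl group of compound 1 still goes beyond the scatter with no amine present: an at least 4.7-fold lower number from compound 1 to compound 3 (0.67 log units; beyond the scatter). Compound 1 gives > 50000 nM, which is a limit of the assay and not a number, so the true size of that step stays open: the limit of > 50000 nM in this assay, at which 1 of the 3 values shown sits.

The compounds shown leave open whether the defined stereocentre in 1-(hydroxymethyl)ethyl matters, as they hold only this one form of it. They also leave open how a carboxylic acid, a longer chain ending in an amine, or a plain alkyl chain with neither nitrogen nor oxygen would read on the amide-type nitrogen.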